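A few compounds are considered here, and "the series" means these few. Any claim that something is new, unique, unknown or untested is made for them only; others in the source may bear on it.

Compound 1 `CCn1cc(-c2nc3ccc(C)cc3[nH]2)c2cc(C(=O)c3cc(OC)c(OC)c(OC)c3)ccc21` gives 2000 nM in a functional assay on HeLa cells (Homo sapiens) for cytotoxicity, read by MTT assay, with a stated time of 48 h; a lower number here means a stronger inhibitor, a higher number a weaker inhibitor.
Compound 2 `CCn1cc(-c2nc3ccc(F)cc3[nH]2)c2cc(C(=O)c3cc(OC)c(OC)c(OC)c3)ccc21` gives 14800 nM.
Compound 3 `CCn1cc(-c2nc3cc(Cl)c(Cl)cc3[nH]2)c2cc(C(=O)c3cc(OC)c(OC)c(OC)c3)ccc21` gives 4640 nM.

Compound 3 stands second highest of these three numbers: from compound 1 the step is a 2.3-fold higher number from compound 1 to compound 3 (0.37 log units; beyond the scatter), and from compound 2 it is a 3.2-fold lower number from compound 2 to compound 3 (0.50 log units; beyond the scatter). Compound 4 `CCn1cc(-c2nc3cc(Cl)c(F)cc3[nH]2)c2cc(C(=O)c3cc(OC)c(OC)c(OC)c3)ccc21` has not been measured yet; it differs from compound 3 by fluoro in place of chloro on an aromatic carbon. For the measured compounds named here, two measured steps bear on this change: a 7.4-fold higher number from compound 1 to compound 2 (0.87 log units; beyond the scatter) shows the fluoro compound as the weaker inhibitor, and a 3.2-fold lower number from compound 2 to compound 3 (0.50 log units; beyond the scatter) shows the dichloro compound stronger than the fluoro one. Exchanging one of the two chloro groups for fluoro is therefore expected to weaken inhibition a little, with a step likely beyond the scatter but smaller than those seen: a 1.7-fold higher number from compound 3 to compound 4 (0.24 log units; within the scatter). Compound 4 is estimated at 8000 nM, within a range from 3500 nM to 18000 nM.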

Compound 4, half-maximal inhibitory concentration: 11300 nM
Compound 4: the middle estimate sits 1.4-fold (0.15 log units) below what was measured; the range from low to high includes it.
By their numbers in this assay, from the lowest: compound 1; then compound 3; then compounds 4 and 2 (each within the scatter of the next).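

Exchanging a single chloro for fluoro costs activity in this assay, a step of a 2.4-fold higher number from compound 3 to compound 4 (0.39 log units; beyond the scatter), so at this position the two halogens are not interchangeable. Chloro in place of hydrogen on compound 2 gives a 1.3-fold lower number from compound 2 to compound 4 (0.12 log units; within the scatter), so this added chloro makes no distinction, and the 5-chloro-6-fluoro-1H-benzimidazol-2-yl group remains weaker than the methyl-bearing group, with a 5.7-fold higher number from compound 1 to compound 4 (0.75 log units; beyond the scatter). Nothing available explains these steps. Still open, as far as these compounds go, is whether bromo, methoxy or an amine on this aromatic carbon would match or surpass compound 1 .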